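The source may hold more compounds than are shown below. What is called first, only, known or untested is meant among the compounds shown, and "the series" means these compounds.

Measured compounds in a functional assay on MRC5 cells (Homo sapiens); on this read-out higher numbers stand for lower toxicity in this test and lower numbers for higher toxicity in this test:
- Compound 1 `O=C1c2ccccc2N(Cc2ccc([N+](=O)[O-])cc2)S(=O)(=O)N1Cc1ccccc1` gives > 59000 nM in this assay; this value is a limit of the assay.
- Compound 2 `O=C1c2ccccc2N(Cc2cccc(Cl)c2)S(=O)(=O)N1Cc1ccccc1` gives 60000 nM in this assay.
- Compound 3 `O=C1c2ccccc2N(CC2CCCCC2)S(=O)(=O)N1Cc1ccccc1` gives > 65000 nM in this assay; this value is a limit of the assay.

Compound 3 stands only at a limit on this read-out, and one further value in the set is likewise a limit (the limit of > 65000 nM in this assay, at which 1 of the 3 values shown sits). Compound 4 `CC(C)CN1c2ccccc2C(=O)N(Cc2ccccc2)S1(=O)=O` differs from compound 3 by isopropyl in place of cyclohexyl on a saturated chain carbon bound to a sulfonamide nitrogen in a ring; cut one bond further out, the change reads cyclohexylmethyl to isobutyl.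

For the measured compounds named here, of the measured steps, the one from compound 2 to compound 3 is the nearest comparison: an at least 1.0-fold higher number from compound 2 to compound 3 (0.03 log units; that floor lies within the scatter), a floor that lies within the scatter. The steps from compound 1 to compound 2 a step that the limit leaves unreadable from compound 1 to compound 2 and from compound 1 to compound 3 a step that the two limits leave unreadable from compound 1 to compound 3 are left unreadable by the limits (the limit of > 59000 nM in this assay, at which 1 of the 3 values shown sits). All three values therefore sit in the same region, and nothing in the set indicates that exchanging the group on this chain carbon shifts the read-out beyond the scatter. No step beyond the scatter is expected in this assay, and the estimated step is a number no higher from compound 3 to compound 4 (the limit leaves the size open). Compound 4 is expected at 65000 nM, in a range from 35000 nM to 120000 nM, most likely again reported only as a limit.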

Compound 4, half-maximal cytotoxic concentration: 72000 nM
For compound 4 the middle estimate is 1.1-fold (0.04 log units) below the measured one; the range from low to high includes it.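

In this assay, for the compounds shown here, isopropyl on a saturated chain carbon bound to a sulfonamide nitrogen in a ring is the first group that carries no ring at this place, and the one readable comparison with a ring-bearing group is a 1.2-fold higher number from compound 2 to compound 4 (0.08 log units; within the scatter). The ring in this group, whether aromatic as in 3-chlorophenyl or saturated as in cyclohexyl, is therefore not needed for a value in this region of the read-out, and replacing cyclohexyl, with 6 heavy atoms, by isopropyl, with 3 heavy atoms, brings no sign of a shift among the compounds that can be compared. The steps to compound 4 from compound 1 and from compound 3 cannot be read, as the values of those two compounds are limits of the assay.

As far as these compounds go, whether any group at this place can move the read-out beyond the scatter stays open, for example an amine, a carboxylic acid or a longer chain carrying either of them. The compounds shown also keep everything else on the shared core the same, so the effect of a change elsewhere on that core is unknown.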